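The source may hold more compounds than are shown below. What is called first, only, known or untested is meant among the compounds shown, and "the series" means these compounds.

For the measured compounds named here, compound 2 `NC(=O)c1c(NC(=O)c2ccc(C(F)(F)F)cc2)sc2c1CCN(C(=S)Nc1ccccc1Cl)C2` is one of two compounds measured in a functional assay on HeLa cells (Homo sapiens) for antiproliferative activity, with a stated time of 24 h; on this read-out higher numbers stand for weaker inhibition and lower numbers for stronger inhibition; compound 2 gives 44000 nM, which is the higher of the two numbers. Its nearest neighbour is compound 1 `Cc1ccccc1C(=O)Nc1sc2c(c1C(N)=O)CCN(C(=S)Nc1ccccc1Cl)C2`, which in this assay gives 35300 nM, and the gap between them lies within the scatter. Going by the values given here, the only step recorded, a 1.2-fold higher number from compound 1 to compound 2 (0.10 log units; within the scatter), exchanges one aryl group on the carbonyl carbon for another and does not move the number beyond the scatter. Compound 3 `Cc1ccc(C(=O)Nc2sc3c(c2C(N)=O)CCN(C(=S)Nc2ccccc2Cl)C3)cc1` differs from compound 2 by methyl in place of trifluoromethyl on an aromatic carbon. Among the compounds with values here, the one step that bears on such an exchange of a substituent on the aryl ring, the step from compound 1 to compound 2, was within the scatter, so no shift beyond the scatter is expected in this assay for compound 3, and the expected step is a 1.1-fold lower number from compound 2 to compound 3 (0.04 log units; within the scatter). Compound 3 is therefore estimated at 40000 nM, in the range 15000 nM to 110000 nM.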

Compound 3, half-maximal inhibitory concentration: 26300 nM
The estimate for compound 3 lay 1.5-fold (0.18 log units) above the measured number; the measured number falls inside the stated range.
By their numbers in this assay, from the lowest: compounds 3, 1 and 2 (each within the scatter of the next).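

Within this assay, methyl in place of trifluoromethyl on an aromatic carbon, para to a large group, gives a 1.7-fold lower number from compound 2 to compound 3 (0.22 log units; within the scatter) and so leaves the number within the scatter. The exchange of 2-methylphenyl for 4-methylphenyl on the carbonyl carbon, which isolates where the methyl group sits on the aryl ring, gives a 1.3-fold lower number from compound 1 to compound 3 (0.13 log units; within the scatter) and also stays within the scatter. No available evidence accounts for these results.

All three compounds lie within the scatter of one another, so these aryl groups give no reading of which features on this ring matter in this assay. From the compounds shown here alone, whether an amine, a carboxylic acid or a methoxy group at this para position would shift the number beyond the scatter remains open.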